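This account rests on a few compounds, and the source may have more. Where it says the series, first, only, none or still open, it means among the compounds named here.

Measured so far in a functional assay on CCRF-CEM cells (Homo sapiens) for inhibition, read by cell counting, with a stated time of 72 h; a higher number here means a weaker inhibitor, a lower number a stronger inhibitor:
- compound 1 `CCN(CC)CN1C(=O)/C(=N/NC(N)=S)c2cc(Cl)ccc21` gives 71000 nM
- compound 2 `CCN(CC)CN1C(=O)/C(=N/NC(=S)Nc2ccccc2)c2ccccc21` gives 11000 nM

Compound 1 holds the higher of the two numbers, which makes it the weaker inhibitor of the pair, and its gap to compound 2 lies beyond the scatter. Next comes compound 3 `CCN(CC)CN1C(=O)/C(=N/NC(=S)Nc2ccc(Cl)cc2)c2cc(Cl)ccc21`, not yet measured. Compared with compound 1, it has 4-chlorophenyl in place of hydrogen on an amide-type nitrogen. Within the data shown here, no measured step isolates this change, so its size cannot be read directly, and two compounds establish no trend. Compound 1 does sit at the top of this small range, and compound 2 at 11000 nM shows that a much lower number is reachable in the series. A drop beyond the scatter is therefore expected in this assay. The expected change is a 10-fold lower number from compound 1 to compound 3 (1.01 log units; beyond the scatter) as an estimate only. For compound 3 the estimated value is 7000 nM with an expected range from 2000 nM to 25000 nM in this read-out.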

Compound 3, half-maximal inhibitory concentration: > 125000 nM
Compound 3: only a limit was reported; the forecaster's own chance of this, stated with the estimate: 5%; middle value at least 17-fold (1.25 log units) away from the limit.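

In this assay compound 3 gives > 125000 nM, which is a limit of the assay and not a number, so the reading at this position rests on a bound: the limit of > 125000 nM in this assay, at which 1 of the 3 values shown sits.

On these data alone, putting 4-chlorophenyl in place of hydrogen on an amide-type nitrogen, whose other neighbour is the thiocarbonyl carbon, gives an at least 1.7-fold higher number from compound 1 to compound 3 (0.24 log units; that floor lies within the scatter), so this change brought no lower number and the true size of the step stays unknown. Among these compounds, this is the first single change read, and it gives no support for reading compound 2 at 11000 nM as the result of an aromatic ring on this nitrogen alone.

Among the compounds shown here, compound 2 and compound 3 differ in more than one place, so no step links them and the part played by the chlorine on the core cannot be read from these compounds. Also open, as far as these compounds go, is what a methyl group, a benzyl group or a 4-methoxyphenyl group on the same nitrogen would give in this assay.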